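The source may report more compounds than this note shows. Statements on the series, on what has been measured and on what is new or still open speak of the compounds shown alone.

Measured so far:
compound 1, `Cc1nc(NC(=O)c2ccccc2)sc1C(=O)/C=C/c1ccccc1` — 73.5%
compound 2, `COc1cc(/C=C/C(=O)c2sc(NC(=O)c3ccccc3)nc2C)cc(OC)c1OC` — 100%

Both were run in an assay for inhibition of Polyunsaturated fatty acid 5-lipoxygenase (Homo sapiens), read by spectrophotometry, tested at 10 uM, in the presence of a further agent that is not named here; a higher number here means more inhibition at the concentration tested (going by the name of the read-out), a lower number less inhibition. Of the two numbers compound 1 stands lowest; compound 2 lies higher by a margin beyond the usual scatter of this assay. Among the compounds with values here, no single-point step between measured compounds is available, so the stretch from compound 1 to compound 2 is the only comparison in hand.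

Compound 3, `Cc1ccc(/C=C/C(=O)c2sc(NC(=O)c3ccccc3)nc2C)cc1`, has not yet been run in this assay. It differs from compound 1 in one place: methyl in place of hydrogen on an aromatic carbon. Within the data shown here, this is a smaller change than the one separating compound 1 from compound 2, and no step of exactly this kind is known. Since compound 2 reaches 100%, an upward move for the methyl compound is plausible, though it need not pass beyond the scatter. The expected step is a number 6.5 percentage points higher from compound 1 to compound 3 (within the scatter) in this assay. For compound 3 the estimate is 80%, with a range from 62% to 96%.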

Compound 3, a percentage reported as inhibition, at one concentration (the size of the read-out at that concentration, not a potency): 75.1%
The estimate for compound 3 lay 4.9 percentage points above the measured number, within the range that was stated.
By their numbers in this assay, from the lowest: compounds 1 and 3 (each within the scatter of the next); then compound 2.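

In this assay, within the data shown here, the first single-place step, phenyl to 4-methylphenyl, gives a number 1.6 percentage points higher from compound 1 to compound 3 (within the scatter). At this position, para to a large group on the six-membered aromatic ring of carbon only, adding one methyl therefore produces no difference that can be separated from assay scatter, so compound 1 and compound 3 cannot be ranked. No available evidence bears on this result.

Open, on these data alone, is whether this position stays equally insensitive to a hydroxyl, an amine or a carboxylic acid, or to a longer chain such as ethyl or butyl. Also open, as far as these compounds go, is whether a methyl on another aromatic carbon of the same ring would give a step of similar size.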